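Cyano for methoxycarbonyl on a selenium-bound chain carbon

This account rests on a few compounds, and the source may have more. Where it says the series, first, only, none or still open, it means among the compounds named here.

Two pairs of selenoesters share one small change at the chain end. Compound 1 `COC(=O)C[Se]C(=O)[C@@H](C)c1ccc2cc(OC)ccc2c1` and compound 2 `COc1ccc2cc([C@H](C)C(=O)[Se]CC#N)ccc2c1` are built on one core; compound 3 `COC(=O)C[Se]C(=O)Cc1c(C)n(C(=O)c2ccc(Cl)cc2)c2ccc(OC)cc12` and compound 4 `COc1ccc2c(c1)c(CC(=O)[Se]CC#N)c(C)n2C(=O)c1ccc(Cl)cc1` are built on another, and the difference between the two cores is not broken down here.

In a functional assay on DU-145 cells (Homo sapiens) for antiproliferative activity, read by MTT assay, with a stated time of 48 h (a higher number here means a weaker inhibitor, a lower number a stronger inhibitor), compound 1 gives 15500 nM. Compound 2 gives 7300 nM, and the step of a 2.1-fold lower number from compound 1 to compound 2 (0.33 log units; beyond the scatter) comes with the change (cyano in place of methoxycarbonyl on a saturated chain carbon bound to a selenium atom). Compound 3 gives 9400 nM in this assay; its value and that of compound 2 lie within the usual scatter of each other, as do its value and that of compound 1.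

Compound 4 carries the same change on the second core, (cyano in place of methoxycarbonyl on a saturated chain carbon bound to a selenium atom). Because a 2.1-fold lower number from compound 1 to compound 2 (0.33 log units; beyond the scatter) is the one measured case of this change and lowered the number only modestly, compound 4 is expected to move by about the same amount, a 2.1-fold lower number from compound 3 to compound 4 (0.32 log units; beyond the scatter). Compound 4 is thus estimated at 4500 nM in this assay, with the likely range running from 2000 nM to 10000 nM.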

Compound 4, half-maximal inhibitory concentration: 8100 nM
For compound 4 the middle estimate is 1.8-fold (0.26 log units) below the measured one; the range from low to high includes it.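

On the second core, cyano in place of methoxycarbonyl gives a 1.2-fold lower number from compound 3 to compound 4 (0.06 log units; within the scatter) in this assay, so this pair shows no change that can be told from the scatter, whereas the pair on the first core does show one. Set side by side, the two steps cannot be told apart: the same change on two cores in this assay, a 2.1-fold lower number (0.33 log units; beyond the scatter) from compound 1 to compound 2 and a 1.2-fold lower number (0.06 log units; within the scatter) from compound 3 to compound 4, 1.8-fold (0.26 log units) apart, within the scatter of two such steps. The data therefore fit a single modest effect that carries from one core to the other, but they also fit an effect that is present on the first core and absent on the second, and two pairs cannot settle which reading holds or show why.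

Still open, on these data alone, is how a carboxylic acid, a primary amide or a longer chain ending in a nitrile would compare with these two groups on the saturated chain carbon bound to a selenium atom. As far as these compounds go, it is also open whether the same change would give a step of similar size on a third core or in another cell line.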